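A few compounds are considered here, and "the series" means these few. Any claim that something is new, unique, unknown or untested is made for them only; others in the source may bear on it.

Measured so far:
compound 1 `O=C(NNc1cccc(Cl)c1)c1ccc(NS(=O)(=O)c2cnc(O)nc2O)cc1` — 8410 nM
compound 2 `Cc1ccccc1NNC(=O)c1cccc(NS(=O)(=O)c2cnc(O)nc2O)c1` — > 20000 nM

Among the measured compounds shown here, in a functional assay on OVCAR-3 cells (Homo sapiens) for antiproliferative activity, read by MTT assay, with a stated time of 24 h (on this read-out higher numbers stand for weaker inhibition and lower numbers for stronger inhibition), compound 1 gives 8410 nM, the only plain number among the two results. Compound 2 reaches only > 20000 nM, which is a limit of the assay rather than a number (the limit of > 20000 nM in this assay, at which 1 of the 2 values shown sits). Compound 3 `O=C(NNC(=O)c1cccc(Cl)c1)c1ccc(NS(=O)(=O)c2cnc(O)nc2O)cc1` is not yet measured and differs from compound 1 by a single change: (3-chlorophenyl)carbonyl in place of 3-chlorophenyl on an amine nitrogen. Nothing measured here tells how such a change behaves, so the expected step is small, with no clear direction beyond the usual scatter a 1.2-fold higher number from compound 1 to compound 3 (0.08 log units; within the scatter). Compound 3 is therefore estimated at about 10000 nM, within a range from 3000 nM to 30000 nM.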

Compound 3, half-maximal inhibitory concentration: 7710 nM
The estimate for compound 3 lay 1.3-fold (0.11 log units) above the measured number; the measured number falls inside the stated range.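

Among the compounds shown here, the step from compound 1 to compound 3 in this assay is a 1.1-fold lower number from compound 1 to compound 3 (0.04 log units; within the scatter), so this is the first reading at this amine nitrogen. Swapping 3-chlorophenyl for (3-chlorophenyl)carbonyl adds heavy atoms and a hydrogen-bond acceptor, yet the number does not leave the usual scatter, so this position accepts this change in this assay. No measurement shown here bears on why that is so. Still open, as far as these compounds go, is how this nitrogen would respond to a group without the chlorophenyl ring, such as a carboxylic acid, an amine or a longer alkyl chain.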